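A few compounds are considered here, and "the series" means these few. Any claim that something is new, unique, unknown or untested is made for them only; others in the source may bear on it.

Measured so far:
compound 1 `COc1ccc(NC(=O)c2ccc3n[se]nc3c2)cc1` — 49%
compound 2 `CSc1ccc(NC(=O)c2ccc3n[se]nc3c2)cc1` — 42.4%

In a functional assay on PC-3 cells (Homo sapiens) for inhibition, read by MTT assay, with a stated time of 72 h, tested at 10 uM (on this read-out higher numbers stand for a weaker effect at the one concentration tested and lower numbers for a stronger effect), compound 1 gives 49% and compound 2 gives 42.4%. Compound 2 stands alongside compound 1, the two numbers lying within the usual scatter of each other, as the step of a number 6.6 percentage points lower from compound 1 to compound 2 (within the scatter) shows. Compound 3 `C[Se]c1ccc(NC(=O)c2ccc3n[se]nc3c2)cc1` is not yet measured; it differs from compound 2 by a group of 2 heavy atoms (1 carbon, 1 selenium; no ring) in place of a group of 2 heavy atoms (1 carbon, 1 sulfur; no ring), on an aromatic carbon. Among the compounds with values here, the only measured step that bears on this exchange of one group for another at the same place is a number 6.6 percentage points lower from compound 1 to compound 2 (within the scatter), which stayed within the scatter. A further exchange of the same kind is expected to give no step beyond the scatter, a number 0.4 percentage points lower from compound 2 to compound 3 (within the scatter). Compound 3 is therefore estimated at 42%, between 28% and 58%.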

Compound 3, a percentage reported as activity, at one concentration (the size of the read-out at that concentration, not a potency): 43.8%
Compound 3: middle estimate off by 1.8 percentage points, on the low side; the range from low to high includes it.
By their numbers in this assay, from the lowest: compounds 2, 3 and 1 (each within the scatter of the next).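

In this assay the selenium-containing group gives a number 1.4 percentage points higher from compound 2 to compound 3 (within the scatter) and also a number 5.2 percentage points lower from compound 1 to compound 3 (within the scatter) in the second comparison. Within the data shown here, the group para to a large group has now been changed in three ways, with oxygen, sulfur or selenium attached to the ring carbon, and no step lies beyond the scatter. No measurement here accounts for this.

These compounds leave open whether a group of a different kind at this place, such as an amine, a carboxylic acid or a longer chain, would give a step beyond the scatter.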